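Working notes: replacing the group on the carbonyl carbon

The source may report more compounds than this note shows. Statements on the series, on what has been measured and on what is new or still open speak of the compounds shown alone.

In a physicochemical assay for lipophilicity, read by HPLC, in phosphate buffer, measured as octanol-water partition, with a stated time of 1 h, at pH 7.4 (on this read-out higher numbers stand for higher lipophilicity and lower numbers for lower lipophilicity), compound 3 `C[C@@]1(c2cc(NC(=O)c3ccc(C#N)cn3)ccc2F)C=C(CF)OC(N)=N1` gives 2.3. Compound 1 `C[C@@]1(c2cc(NC(=O)c3cnc(C(F)F)cn3)ccc2F)C=C(CF)OC(N)=N1` gives 2.5, and the measured step is a number 0.20 log units lower from compound 1 to compound 3 (within the scatter). Compound 2 `C[C@@]1(c2cc(NC(=O)c3ncc(OCF)nc3N)ccc2F)C=C(CF)OC(N)=N1` gives 3.1, and the measured step is a number 0.80 log units lower from compound 2 to compound 3 (beyond the scatter). Compound 4 `COc1cnc(C(=O)Nc2ccc(F)c([C@]3(C)C=C(CF)OC(N)=N3)c2)cn1` differs from compound 3 as follows: 5-methoxypyrazin-2-yl in place of 5-cyanopyridin-2-yl on a carbonyl carbon. Both steps bear on this change, read in reverse, since each ends in 5-cyanopyridin-2-yl. The closer precedent is compound 1, with its 5-(difluoromethyl)pyrazin-2-yl and its step of a number 0.20 log units lower from compound 1 to compound 3 (within the scatter), while compound 2 also carries an amino group. A small upward move within the scatter is therefore expected, the expected step being a number 0.20 log units higher from compound 3 to compound 4 (within the scatter). Compound 4 is estimated at 2.5, with an expected range of 2.2 to 2.9.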

Compound 4, distribution coefficient: 2.7
For compound 4 the middle estimate is 0.20 log units below the measured one; measured number inside the range.
By their numbers in this assay, from the lowest: compounds 3, 1 and 4 (each within the scatter of the next, the first and the last beyond it); then compound 2.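

In this assay, going by these compounds alone, 5-methoxypyrazin-2-yl in place of 5-cyanopyridin-2-yl on a carbonyl carbon gives a number 0.40 log units higher from compound 3 to compound 4 (beyond the scatter) and is the first step beyond the scatter at this position that involves no amino group. Methoxy in place of difluoromethyl on an aromatic carbon gives a number 0.20 log units higher from compound 1 to compound 4 (within the scatter) and does not separate those two groups. 5-Methoxypyrazin-2-yl in place of 3-amino-5-(fluoromethoxy)pyrazin-2-yl gives a number 0.40 log units lower from compound 2 to compound 4 (beyond the scatter) and keeps compound 2 apart from the other three.

No measured evidence explains these steps. As far as these compounds go, the separate contributions of the amino group and the fluoromethoxy group remain open, as does the reading for a carboxylic acid at this position.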